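The source may report more compounds than this note shows. Statements on the series, on what has been measured and on what is new or still open speak of the compounds shown alone.

Measured compounds:
compound 1 `CCc1cnccc1-c1csc(Nc2cccc(C)c2)n1`: 6310 nM
compound 2 `Cc1cccc(Nc2nc(-c3ccncc3Cl)cs2)c1`: 2950 nM
compound 3 `Cc1cccc(Nc2nc(-c3ccncc3N3CCN(C)CC3)cs2)c1`: 2600 nM; 2630 nM (2 entries)

Working notes. Among the compounds with values here, in a functional assay on RCC4 cells (Homo sapiens) for inhibition, read by XTT assay, with a stated time of 4 days (a higher number here means a weaker inhibitor, a lower number a stronger inhibitor), compound 2 holds the lowest of the two single numbers; the only measured one-place step in the set is a 2.1-fold lower number from compound 1 to compound 2 (0.33 log units; beyond the scatter), a modest change that lies beyond the scatter. Compound 3 has no single number but several entries, (the several entries of compound 3 in this assay, 2600 nM; 2630 nM (2 entries)), and these sit near the value of compound 2, so nothing beyond the scatter separates the two.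

Compound 4 `Cc1cccc(Nc2nc(-c3ccncc3Br)cs2)c1` is not yet measured. Its difference from compound 2 is bromo in place of chloro on an aromatic carbon. Within the data shown here, no measured step swaps one halogen for another at this position; the one step that touches the place, chloro for ethyl, gave only a modest shift, and a bromo for chloro exchange is a smaller change than that. The expected step in this assay is therefore a 1.2-fold lower number from compound 2 to compound 4 (0.07 log units; within the scatter), that is, none beyond the scatter. Compound 4 is estimated at 2500 nM, with a range from 1000 nM to 6000 nM.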

Compound 4, half-maximal inhibitory concentration: 3980 nM
Compound 4: middle estimate off by 1.6-fold (0.20 log units), on the low side, within the range that was stated.
By their numbers in this assay, from the lowest: compounds 2, 4 and 1 (each within the scatter of the next, the first and the last beyond it).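

In this assay, the exchange of one halogen for another at this position, on an aromatic carbon two atoms from the ring nitrogen, gives a 1.3-fold higher number from compound 2 to compound 4 (0.13 log units; within the scatter), so chloro and bromo are not separated here. Bromo in place of ethyl gives a 1.6-fold lower number from compound 1 to compound 4 (0.20 log units; within the scatter), while chloro in place of ethyl gave a 2.1-fold lower number from compound 1 to compound 2 (0.33 log units; beyond the scatter); the separation from ethyl beyond the scatter therefore holds for chloro only, and compound 4 does not share it. No measurement at hand gives a cause for either step.

Open, as far as these compounds go, is whether a fluoro, a methoxy or a carboxylic acid at this position would give a step beyond the scatter. Also open, from the compounds shown here alone, is whether the same exchange of chloro for bromo behaves alike on a changed core.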